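The compounds below may be only part of what the source reports. "The series", "measured", "known", "first", "only" and "open" are said of these compounds alone.

Measured so far:
compound 1 `CC(Nc1c(C#N)c(-c2ccc(Br)cc2)nc2cnccc12)C(N)=O` — 2.1
compound 2 `CC[C@@H](Nc1c(C#N)c(-c2ccc(-c3ccccc3OC)cc2)nc2cnccc12)C(N)=O` — 2.7
compound 3 `CCOc1ccccc1-c1ccc(-c2nc3cnccc3cc2C#N)cc1` — 3.8

In a physicochemical assay for lipophilicity, read by HPLC, at pH 7.5 (a lower number here means a more polar compound, a higher number a more lipophilic compound), compound 2 gives 2.7, the second highest of the three numbers. Compound 1 lies nearest, with a value in this assay of 2.1, a step down from compound 2 that is beyond the scatter. Compound 3 lies furthest, with 3.8 in this assay, a step up from compound 2 that is also beyond the scatter. Among the measured compounds shown here, no pair among the three differs in only one place, so no single-change step is known for the series.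

Compound 4 `CC[C@@H](Nc1c(C#N)c(-c2ccc(-c3cnccc3C)cc2)nc2cnccc12)C(N)=O` has not yet been measured in this assay. It differs from compound 2 as follows:
4-methylpyridin-3-yl in place of 2-methoxyphenyl on an aromatic carbon
One hydrogen-bond acceptor leaves and one enters; the ring that enters carries one hetero atom where the ring that leaves has carbon only. For this assay the step from compound 2 to compound 4 is expected to be a decrease beyond the scatter, of about a number 0.80 log units lower from compound 2 to compound 4 (beyond the scatter). Compound 4 is therefore estimated at 1.9 in this assay, within a range from 1.4 to 2.5.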

Compound 4, distribution coefficient: 2
Estimate against measurement, compound 4: 0.10 log units below; low and high end bracket the measured number.
By their numbers in this assay, from the lowest: compounds 4 and 1 (each within the scatter of the next); then compound 2; then compound 3.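

Among the compounds shown here, this gives the first single-change step: in this assay, 4-methylpyridin-3-yl in place of 2-methoxyphenyl, on an aromatic carbon para to a large group, gives a number 0.70 log units lower from compound 2 to compound 4 (beyond the scatter). The position therefore registers this exchange even though the hydrogen-bond donor and acceptor counts match on both sides, while the ring gains one hetero atom and the group loses one heavy atom overall. No measurement at hand accounts for the size of this step.

From the compounds shown here alone, the exchange alters the ring atoms and the ring substituent together, so their separate shares in the step remain open. Also open, going by these compounds, is how groups such as plain phenyl, 2-methylphenyl, or a phenyl carrying a carboxylic acid or an amine would read at this position.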